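Fluoro on the pendant phenyl across two amine tails

The source may report more compounds than this note shows. Statements on the series, on what has been measured and on what is new or still open speak of the compounds shown alone.

Compound 1 `COc1cc2c(Oc3ccc(NC(=O)c4nn(-c5ccccc5)c(=O)c5ccccc45)cc3F)ccnc2cc1OCCCN1CCCC1` is the reference; in a functional assay on MDA-MB-231 cells (Homo sapiens) for cytotoxicity, read by MTT assay, with a stated time of 72 h (a higher number here means a weaker inhibitor, a lower number a stronger inhibitor), compound 1 gives 1130 nM. Compound 2 `COc1cc2c(Oc3ccc(NC(=O)c4nn(-c5cccc(F)c5)c(=O)c5ccccc45)cc3F)ccnc2cc1OCCCN1CCCC1` carries the change (fluoro in place of hydrogen on an aromatic carbon), and in this assay compound 2 gives 880 nM, a step of a 1.3-fold lower number from compound 1 to compound 2 (0.11 log units; within the scatter). Compound 3 `COc1cc2c(Oc3ccc(NC(=O)c4nn(-c5ccccc5)c(=O)c5ccccc45)cc3F)ccnc2cc1OCCCN1CCCCC1` differs from compound 1 by piperidin-1-yl in place of pyrrolidin-1-yl on a saturated chain carbon, three bonds along the chain from an oxygen on an aromatic ring; in this assay compound 3 gives 1880 nM, a step of a 1.7-fold higher number from compound 1 to compound 3 (0.22 log units; within the scatter). The values of compound 2 and compound 3 sit beyond the scatter of each other.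

Compound 4 `COc1cc2c(Oc3ccc(NC(=O)c4nn(-c5ccccc5F)c(=O)c5ccccc45)cc3F)ccnc2cc1OCCCN1CCCCC1` is not yet measured. It differs from compound 3 by fluoro in place of hydrogen on an aromatic carbon. The two cores differ by piperidin-1-yl in place of pyrrolidin-1-yl on a saturated chain carbon, three bonds along the chain from an oxygen on an aromatic ring. The place is not the same as in the earlier pair: there the fluoro sits meta to a large group, here ortho to a large group, so this is the same kind of change, not the same change. Going by the values given here, with only the single earlier step of a 1.3-fold lower number from compound 1 to compound 2 (0.11 log units; within the scatter) to lean on, which lies within the scatter, the step from compound 3 to compound 4 is expected to be a 1.2-fold lower number from compound 3 to compound 4 (0.07 log units; within the scatter). Compound 4 is therefore estimated at 1600 nM, within a range of 700 nM to 3600 nM.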

Compound 4, half-maximal inhibitory concentration: 910 nM
For compound 4 the middle estimate is 1.8-fold (0.25 log units) above the measured one; the measured number falls inside the stated range.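

In this assay, fluoro in place of hydrogen on an aromatic carbon of the phenyl gives a 2.1-fold lower number from compound 3 to compound 4 (0.32 log units; beyond the scatter), a step beyond the scatter on the piperidin-1-yl tail, while the earlier step on the pyrrolidin-1-yl tail stays within it; set side by side, the two steps cannot be told apart: the same change on two cores in this assay, a 1.3-fold lower number (0.11 log units; within the scatter) from compound 1 to compound 2 and a 2.1-fold lower number (0.32 log units; beyond the scatter) from compound 3 to compound 4, 1.6-fold (0.21 log units) apart, within the scatter of two such steps. The pairs therefore give no sign that the result of adding fluoro depends on the core, but this is not proof that it carries over unchanged, as only two pairs are shown. The fluoro is also ortho to a large group in compound 4 only, so the core and the place of the fluoro are not separated.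

The compounds shown leave open how each fluoro placement would read on the other amine tail. They also leave open how a chloro or methoxy group on the phenyl, or a morpholine in place of the tail amine, would read in this assay.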